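A Fluorinated Aryl Group on the Aromatic Nitrogen

This account rests on a few compounds, and the source may have more. Where it says the series, first, only, none or still open, it means among the compounds named here.

Three compounds share one core and differ only in the aryl group carried on an aromatic nitrogen. Compound 1 `Cc1ccc(-n2nc(-c3ccc(C(F)(F)F)cc3O)nc2-c2ccccc2O)cc1` carries a 4-methylphenyl there, and in a functional assay on PC-12 cells (Rattus norvegicus) for cytotoxicity, read by MTT assay, with stated times of 2 h and 24 h, tested at 10 uM (a higher number here means a stronger effect of the compound at the concentration tested, a lower number a weaker effect), compound 1 gives 102%. Compound 2 `Oc1cc(C(F)(F)F)ccc1-c1nc(-c2ccccc2O)n(-c2cccc(Cl)c2)n1` carries a 3-chlorophenyl, and in this assay compound 2 gives 100%. Compound 3 `Cc1ccc(-n2nc(-c3ccc(C(F)(F)F)cc3O)nc2-c2ccccc2O)c(C)c1` carries a 2,4-dimethylphenyl, and in this assay compound 3 gives 106%, the highest of the three numbers, yet the step of a number 4 percentage points higher from compound 1 to compound 3 (within the scatter) and the step of a number 6 percentage points higher from compound 2 to compound 3 (within the scatter) both fall within the usual scatter, so no real order among the three can be claimed.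

Compound 4 `Oc1cc(C(F)(F)F)ccc1-c1nc(-c2ccccc2O)n(-c2cc(F)cc(F)c2)n1` is the next member: 3,5-difluorophenyl in place of 2,4-dimethylphenyl on an aromatic nitrogen. Going by the values given here, the steps that bear on this change are the earlier swaps of the same aryl group, namely a number 2 percentage points lower from compound 1 to compound 2 (within the scatter), a number 6 percentage points higher from compound 2 to compound 3 (within the scatter) and a number 4 percentage points higher from compound 1 to compound 3 (within the scatter), none of which moved the read-out beyond the scatter. The expectation is therefore that the step of a number 4 percentage points lower from compound 3 to compound 4 (within the scatter) in this assay will again stay within the scatter, with no direction to speak of. Compound 4 is accordingly estimated at 102% in this assay, with a range from 92% to 112%.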

Compound 4, a percentage reported as activity, at one concentration (the size of the read-out at that concentration, not a potency): 106%
The estimate for compound 4 lay 4 percentage points below the measured number; the measured number falls inside the stated range.
By their numbers in this assay, from the lowest: compounds 2, 1, 3 and 4 (each within the scatter of the next).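

Fluorine on the aryl ring is new here: in this assay the swap gives no change at the digits printed from compound 3 to compound 4 (within the scatter), and the same 3,5-difluorophenyl group gives a number 6 percentage points higher from compound 2 to compound 4 (within the scatter) and also a number 4 percentage points higher from compound 1 to compound 4 (within the scatter), so all three new steps stay within the scatter. The position on the aromatic nitrogen therefore now holds four aryl groups carrying methyl, chlorine or fluorine, and none of the steps among them can be told apart from repeat-to-repeat variation, even where 2,4-dimethylphenyl and 3,5-difluorophenyl, with the same count of heavy atoms, exchange two carbon atoms for two fluorine atoms. Nothing measured on these groups bears on why the read-out stays so flat.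

From the compounds shown here alone, what remains open is whether any group at this position can move the number at all, for instance a phenyl ring bearing an amine or a carboxylic acid, or a longer alkyl chain in place of the aryl ring. Also open, going by these compounds, is whether the 2-hydroxyphenyl group or the trifluoromethyl-bearing hydroxyphenyl group matters, since both stay the same across all four compounds.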